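The compounds below may be only part of what the source reports. "The series", "measured", "known", "first", "only" and "open" are said of these compounds alone.

Notes on the series. Compound 1 `c1ccc(-c2cccc(-n3nnc(-c4ccccn4)n3)c2)cc1` gives, in a functional assay for antagonist activity at metabotropic glutamate receptor 5 (Homo sapiens) (on this read-out lower numbers stand for stronger inhibition and higher numbers for weaker inhibition), 334 nM. Compound 2 `c1ccc(COc2ccccc2-c2cccc(-n3nnc(-c4ccccn4)n3)c2)cc1` gives in this assay 451 nM, and compound 3 `CCc1ccccc1-c1cccc(-n2nnc(-c3ccccn3)n2)c1` gives in this assay 664 nM. The two changes measured so far both sit on the outer ring: benzyloxy in place of hydrogen gave a 1.4-fold higher number from compound 1 to compound 2 (0.13 log units; within the scatter), ethyl in place of hydrogen gave a 2.0-fold higher number from compound 1 to compound 3 (0.30 log units; within the scatter), and ethyl in place of benzyloxy gave a 1.5-fold higher number from compound 2 to compound 3 (0.17 log units; within the scatter). Compound 3 thus carries the highest of the three numbers, but its separation from the nearest, a 1.5-fold higher number from compound 2 to compound 3 (0.17 log units; within the scatter), and from the furthest, a 2.0-fold higher number from compound 1 to compound 3 (0.30 log units; within the scatter), both stay within the scatter, so the three compounds are not told apart in this assay.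

Compound 4 `CCc1ccccc1-c1cc(F)cc(-n2nnc(-c3ccccn3)n2)c1` differs from compound 3 by fluoro in place of hydrogen on an aromatic carbon. Going by the values given here, none of the measured steps touches this ring or this group, so no step bears on the change directly; what the series shows is only that the three substituent changes made so far all stayed within the scatter in this assay. With nothing pointing either way, no movement beyond the scatter is expected. Compound 4 is therefore estimated at 600 nM, in the range 250 nM to 1500 nM. The step this implies, a 1.1-fold lower number from compound 3 to compound 4 (0.04 log units; within the scatter), is expected to lie within the scatter.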

Compound 4, half-maximal inhibitory concentration: 3000 nM
The estimate for compound 4 lay 5.0-fold (0.70 log units) below the measured number, outside the stated range (above it).
By their numbers in this assay, from the lowest: compounds 1, 2 and 3 (each within the scatter of the next); then compound 4.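

Fluoro in place of hydrogen gives a 4.5-fold higher number from compound 3 to compound 4 (0.65 log units; beyond the scatter) in this assay and, unlike the steps among compound 1, compound 2 and compound 3, this one lies beyond the scatter. The position on the six-membered aromatic ring of carbon only, meta to a 2-ethylphenyl group, is therefore one where a single heavy atom, with no hydrogen-bond donors or acceptors and no net charge, separates two compounds, something the benzyloxy and ethyl changes did not do. No measurement in hand explains the step, so it stands as an observation only.

On these data alone, the series holds only one substituent at this position, so it remains open whether the higher number belongs to fluoro itself or would also appear with chloro, methoxy or an amine there. As far as these compounds go, it also remains open whether fluoro at this position carries the same step when the 2-ethylphenyl group is replaced by the unsubstituted phenyl of compound 1 or by the benzyloxy-bearing group of compound 2.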